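A few compounds are considered here, and "the series" means these few. Any claim that something is new, unique, unknown or untested is made for them only; others in the source may bear on it.

Of the compounds shown here, three built on one shared core have been measured in an assay on isolated protein for inhibition of Indoleamine 2,3-dioxygenase 1 (Homo sapiens), read by spectrophotometry; a higher number here means a weaker inhibitor, a lower number a stronger inhibitor. Compound 1 `O=C(Cc1cccnc1)c1cc2c(Cl)cc(Cl)cc2[nH]1` gives 139000 nM in this assay. Compound 2 `O=C(Cc1cccnc1)c1cc2cc(F)ccc2[nH]1` gives 36000 nM in this assay. Compound 3 `O=C(Cc1cccnc1)c1cc2c(O)cccc2[nH]1` gives 83000 nM in this assay. Among these three numbers compound 3 stands second highest; its value lies within the scatter of that of compound 1, so no order between those two can be read, while compound 2 sits beyond the scatter at the lower end. The unmeasured compound 4 `O=C(Cc1cccnc1)c1cc2ccccc2[nH]1` differs from compound 3 in a single place: hydrogen in place of hydroxy on an aromatic carbon. Within the data shown here, no measured pair among the three shows this particular change, so the data give no direct guide to its size or direction. The step is therefore expected to be modest, most likely within the scatter, with the expected step being a 1.4-fold lower number from compound 3 to compound 4 (0.14 log units; within the scatter) in this assay. Compound 4 is accordingly estimated at 60000 nM in this assay, with a range from 20000 nM to 180000 nM.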

Compound 4, half-maximal inhibitory concentration: 65000 nM
Beside the measured number, compound 4's estimate is 1.1-fold (0.03 log units) below it; low and high end bracket the measured number.
By their numbers in this assay, from the lowest: compounds 2, 4, 3 and 1 (each within the scatter of the next, the first and the last beyond it).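

In this assay hydrogen in place of hydroxy on an aromatic carbon, ortho to a fused ring, gives a 1.3-fold lower number from compound 3 to compound 4 (0.11 log units; within the scatter) and so shows that this hydroxy can be exchanged for hydrogen with no readable change in the number. Hydrogen in place of fluoro on an aromatic carbon gives a 1.8-fold higher number from compound 2 to compound 4 (0.26 log units; within the scatter) and is likewise no readable change, so compound 4 ties compound 2 and compound 3 to one reference point. Nothing shown here explains either step.

As far as these compounds go, whether a methoxy group, an amine or a carboxylic acid on this aromatic carbon would move the number beyond the scatter stays open. From the compounds shown here alone, it also remains open whether a hydroxy group or a fluoro group would give a readable step on any other aromatic carbon of the shared core.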